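Changing the Ester Aryl Group of Compound 1

A few compounds are considered here, and "the series" means these few. Any claim that something is new, unique, unknown or untested is made for them only; others in the source may bear on it.

Three measured compounds share one large core and differ only in the group attached at a single position. Compound 1 `CC1=CC[C@H]2[C@H](CC[C@]2(C)O)C(C)(C)[C@@H]1CC[C@H]1[C@]2(C)CC[C@H](OC(=O)c3ccncc3)C(C)(C)O[C@H]2CC[C@@]1(C)O` carries a ((pyridin-4-yl)carbonyl)oxy group there. In a functional assay on MCF7 cells (Homo sapiens) for antiproliferative activity, read by MTT assay, with a stated time of 72 h (on this read-out lower numbers stand for stronger inhibition and higher numbers for weaker inhibition), compound 1 gives 25300 nM. Compound 2 `CC1=CC[C@H]2[C@@H]1CC=C(C)[C@@H](CC[C@H]1[C@]3(C)CC[C@H](OC(=O)c4ccc(Cl)cc4)C(C)(C)O[C@H]3CC[C@@]1(C)O)C2(C)C` bears a different ester at the same position, and in this assay compound 2 gives 22000 nM, a number that lies within the usual scatter of the number for compound 1, so the two cannot be told apart. Compound 3 `CC1=CC[C@H]2[C@H](CC[C@]2(C)O)C(C)(C)[C@@H]1CC[C@H]1[C@]2(C)CC/C(=N/OCc3ccccc3)C(C)(C)O[C@H]2CC[C@@]1(C)O` has a different kind of linkage in place of the ester; in this assay compound 3 reaches only > 50000 nM, which is a limit of the assay rather than a number (the limit of > 50000 nM in this assay, at which 1 of the 3 values shown sits).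

Compound 4 `CC1=CC[C@H]2[C@H](CC[C@]2(C)O)C(C)(C)[C@@H]1CC[C@H]1[C@]2(C)CC[C@H](OC(=O)c3cccc([N+](=O)[O-])c3)C(C)(C)O[C@H]2CC[C@@]1(C)O` is not yet measured. It differs from compound 1 by 3-nitrophenyl in place of pyridin-4-yl on a carbonyl carbon. Among the measured compounds shown here, with no step between measured compounds to draw on, the change is expected to move the number little, at most within the scatter in either direction. For compound 4 the expected result in this assay is 20000 nM, within 8000 nM to 50000 nM, that is, an expected step of a 1.3-fold lower number from compound 1 to compound 4 (0.10 log units; within the scatter).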

Compound 4, half-maximal inhibitory concentration: 36000 nM
Beside the measured number, compound 4's estimate is 1.8-fold (0.26 log units) below it; low and high end bracket the measured number.
By their numbers in this assay, from the lowest: compounds 2, 1 and 4 (each within the scatter of the next). At a limit, above all of these: compound 3.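

In this assay, 3-nitrophenyl in place of pyridin-4-yl on a carbonyl carbon gives a 1.4-fold higher number from compound 1 to compound 4 (0.15 log units; within the scatter), so compound 1 and compound 4 cannot be told apart. This pair shows that the ring nitrogen of pyridin-4-yl is not needed to keep the number at this level: one six-membered aromatic ring of carbon only, carrying a nitro group, reads the same at this position. No measurement shown here explains why the two numbers match.

Still open, on these data alone, is what a ring carrying an amine or a carboxylic acid would do at this position, and whether the aromatic ring is needed at all. A plain acetyl ester or a longer saturated chain in its place would address that second question.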